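Aryl amide change from compound 3 to compound 4

A few compounds are considered here, and "the series" means these few. Any claim that something is new, unique, unknown or untested is made for them only; others in the source may bear on it.

In a functional assay on MDA-MB-231 cells (Homo sapiens) for cytotoxicity, read by MTT assay, with a stated time of 72 h (a higher number here means a weaker inhibitor, a lower number a stronger inhibitor), compound 1 (`O=C(CN1CCN(c2nnc(Cc3ccncc3)c3ccccc23)CC1)Nc1ccc(Br)cc1`) gives 19 nM, compound 2 (`Cc1ccc(F)cc1NC(=O)CN1CCN(c2nnc(Cc3ccncc3)c3ccccc23)CC1`) gives 6.4 nM and compound 3 (`O=C(CN1CCN(c2nnc(Cc3ccncc3)c3ccccc23)CC1)Nc1cc(C(F)(F)F)ccc1Cl`) gives 3.7 nM on the same core. Compound 3 stands level with compound 2 and clearly apart from compound 1. The step of a 1.7-fold lower number from compound 2 to compound 3 (0.24 log units; within the scatter) stays small, while a 3.0-fold lower number from compound 1 to compound 2 (0.47 log units; beyond the scatter) and a 5.1-fold lower number from compound 1 to compound 3 (0.71 log units; beyond the scatter) are the modest steps that separate compound 1 from the other two.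

Compound 4 (`Cc1cccc(Cl)c1NC(=O)CN1CCN(c2nnc(Cc3ccncc3)c3ccccc23)CC1`) differs from compound 3 as follows: 2-chloro-6-methylphenyl in place of 2-chloro-5-(trifluoromethyl)phenyl on an amide-type nitrogen on the amide-type nitrogen. The chloro group stays, the trifluoromethyl group leaves and a methyl group enters.

The nearest guide is compound 2, which also carries a methyl group on its aryl group, and the step of a 1.7-fold lower number from compound 2 to compound 3 (0.24 log units; within the scatter) shows no separation from compound 3. The two larger steps both start from the 4-bromophenyl group of compound 1, which plays no part in this change. For the measured compounds named here, with only three measured compounds, this is thin support. At most a slight rise in the number is expected.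

The expected change is a 1.9-fold higher number from compound 3 to compound 4 (0.28 log units; within the scatter) in this assay and no step beyond the scatter is foreseen. For compound 4 the estimated value is 7 nM with an expected range from 2.5 nM to 20 nM in this assay.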

Compound 4, half-maximal inhibitory concentration: 2670 nM
Compound 4: middle estimate off by 380-fold (2.58 log units), on the low side; the whole stated range lies below it.
By their numbers in this assay, from the lowest: compounds 3 and 2 (each within the scatter of the next); then compound 1; then compound 4.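

In this assay, for the compounds shown here, the aryl group on the amide-type nitrogen turns out to be far less forgiving than the earlier compounds showed, with a 720-fold higher number from compound 3 to compound 4 (2.86 log units; beyond the scatter) and with the other two steps also large: a 420-fold higher number from compound 2 to compound 4 (2.62 log units; beyond the scatter) and a 140-fold higher number from compound 1 to compound 4 (2.15 log units; beyond the scatter). A chloro group in compound 3 and a methyl group in compound 2 both occur with low numbers, and compounds 1 and 2 stay low without trifluoromethyl, so neither the presence of one of these groups nor the departure of trifluoromethyl accounts for the result on its own terms; the 2-chloro-6-methylphenyl group as a whole sets compound 4 apart from all three others. Nothing available explains this large rise.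

The compounds shown leave open whether the chloro group, the methyl group or only the two together in 2-chloro-6-methylphenyl carry the rise. They also leave open what this assay returns when an amine, a carboxylic acid or a longer chain stands on the aryl group in place of the methyl group.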